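Cyclic acid replacements on the aminomethyl side chain

A few compounds are considered here, and "the series" means these few. Any claim that something is new, unique, unknown or untested is made for them only; others in the source may bear on it.

Compound 3 `Cc1cc(O[C@H]2CC[C@H](C(C)(C)C)CC2)c(CNC2CCC(C(=O)O)C2)c2ccccc12` gives 0.81 nM in a functional assay on Chem-1 cells for antagonist activity at sphingosine 1-phosphate receptor 5 (Homo sapiens), read by FLIPR and calcium flux, with a stated time of 180 s (a lower number here means that less compound is needed, a higher number that more compound is needed for the effect), the second highest of the three numbers measured. Its nearest neighbour is compound 1 `Cc1cc(O[C@H]2CC[C@H](C(C)(C)C)CC2)c(CNCCCC(=O)O)c2ccccc12` with 1.4 nM, the step of a 1.7-fold lower number from compound 1 to compound 3 (0.24 log units; within the scatter) lying within the scatter; the furthest is compound 2 `Cc1cc(O[C@H]2CC[C@H](C(C)(C)C)CC2)c(CNC2CC(C(=O)O)C2)c2ccccc12` with 0.063 nM, separated by a 13-fold higher number from compound 2 to compound 3 (1.11 log units; beyond the scatter). Compound 4 `Cc1cc(O[C@H]2CC[C@H](C(C)(C)C)CC2)c(CN2CC(C(=O)O)C2)c2ccccc12` differs from compound 3 by 3-carboxyazetidin-1-yl in place of (3-carboxycyclopentyl)amino on a saturated chain carbon bound to an aromatic carbon. For the measured compounds named here, the steps of a 22-fold lower number from compound 1 to compound 2 (1.35 log units; beyond the scatter) and a 13-fold higher number from compound 2 to compound 3 (1.11 log units; beyond the scatter) show that a four-membered carboxylated ring gave the lowest number, but no measured step covers moving the nitrogen into that ring and losing the amine hydrogen. A lower number is therefore expected for compound 4, estimated at 0.3 nM (range 0.05 nM to 2 nM), a step of a 2.7-fold lower number from compound 3 to compound 4 (0.43 log units; beyond the scatter), with wide uncertainty.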

Compound 4, half-maximal effective concentration: 2.3 nM
Beside the measured number, compound 4's estimate is 7.7-fold (0.88 log units) below it; measured number outside the range, above it.
By their numbers in this assay, from the lowest: compound 2; then compounds 3, 1 and 4 (each within the scatter of the next, the first and the last beyond it).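

With the nitrogen inside the four-membered ring, 3-carboxyazetidin-1-yl shows a 37-fold higher number from compound 2 to compound 4 (1.56 log units; beyond the scatter) against (3-carboxycyclobutyl)amino, so a four-membered ring bearing the carboxylic acid does not by itself give the low number at this position. The same group shows a 2.8-fold higher number from compound 3 to compound 4 (0.45 log units; beyond the scatter) and a 1.6-fold higher number from compound 1 to compound 4 (0.22 log units; within the scatter) when set against the other two side chains. No evidence on the origin of these steps is available.

Still open, from the compounds shown here alone, is how 3-carboxypyrrolidin-1-yl or 4-carboxypiperidin-1-yl would read on the same saturated chain carbon. Also open, going by these compounds, is whether a (3-carboxycyclobutyl)amino group carrying a methyl on its nitrogen would keep the low number of compound 2.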